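Stretching the Linker Toward a Measurable Inhibitor

The source may report more compounds than this note shows. Statements on the series, on what has been measured and on what is new or still open speak of the compounds shown alone.

Compound 1 `CN(c1ccc(OCCCC(=O)NO)cc1)c1ncnc2ccccc12` inhibits in an assay on isolated protein for inhibition of histone deacetylase 8 (Homo sapiens), read by fluorescence, with a stated time of 1 h (a lower number here means a stronger inhibitor, a higher number a weaker inhibitor), with 2460 nM. Compound 2 `Cc1nc(N(C)c2cccc(OCC(=O)NO)c2)c2ccccc2n1` is known in this assay only as a limit, > 1000 nM, so its true strength is not fixed (the limit of > 1000 nM in this assay, at which 1 of the 2 values shown sits). Compound 3 `Cc1nc(N(C)c2cccc(OCCCC(=O)NO)c2)c2ccccc2n1` differs from compound 2 in one place: 2-(hydroxycarbamoyl)ethyl in place of hydroxycarbamoyl on a saturated chain carbon bound to an oxygen on an aromatic ring. For the measured compounds named here, no measured pair shows this change directly; compound 1, which carries the same longer chain on a different core, gives 2460 nM. The expected step from compound 2 to compound 3 is a modest gain, a step that the limit leaves unreadable from compound 2 to compound 3. Compound 3 is estimated at 2500 nM, within 600 nM to 10000 nM.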

Compound 3, half-maximal inhibitory concentration: > 1000 nM
Compound 3 ended at the assay's limit; the forecaster's own chance of this, stated with the estimate: 30%; the middle value lies beyond the limit too.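

No step between compound 2 and compound 3 can be read in this assay, since both results are limits rather than numbers: the limit of > 1000 nM in this assay, at which 2 of the 3 values shown sit.

On these data alone, the true strengths of compound 2 and compound 3 remain open, and so does whether 2-(hydroxycarbamoyl)ethyl in place of hydroxycarbamoyl changes inhibition at all.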